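The source may hold more compounds than are shown below. What is called first, only, known or untested is meant among the compounds shown, and "the series" means these compounds.

Compound 1 `CC(Oc1ccccc1)C(=O)Nc1ccc(OCC(=O)O)c(F)c1` is the starting point of this comparison. Among the compounds with values here, in a functional assay on CHO cells for agonist activity at Free fatty acid receptor 1 (Homo sapiens), read by FLIPR, tested at 100 nM (a higher number here means a stronger effect of the compound at the concentration tested, a lower number a weaker effect), compound 1 gives 35.7%, the highest of the three numbers measured so far. Compound 3 `CC(Oc1cccc(C(C)(C)C)c1)C(=O)Nc1ccc(OCC(=O)O)c(F)c1` gives 32.8%, and the change a number 2.9 percentage points lower from compound 1 to compound 3 (within the scatter) lies within the scatter, so the two cannot be told apart. Compound 2 `CC(C)(Oc1ccccc1)C(=O)Nc1ccc(OCC(=O)O)c(F)c1` gives 3.56%, and the change a number 32.1 percentage points lower from compound 1 to compound 2 (beyond the scatter) is large and well beyond the scatter. Compound 4 `CCOc1ccc(OC(C)C(=O)Nc2ccc(OCC(=O)O)c(F)c2)cc1` has not yet been measured. It differs from compound 1 in one place: ethoxy in place of hydrogen on an aromatic carbon The closest guide among the measured steps is a number 2.9 percentage points lower from compound 1 to compound 3 (within the scatter), which likewise concerned a substituent added to the same aromatic ring. The large drop a number 32.1 percentage points lower from compound 1 to compound 2 (beyond the scatter) concerns a saturated chain carbon and a different kind of change, so it gives no direct guide here. A step within the scatter is therefore expected, a number 1.7 percentage points lower from compound 1 to compound 4 (within the scatter). Compound 4 is estimated to give 34%, with a range from 18% to 50%.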

Compound 4, a percentage reported as activity, at one concentration (the size of the read-out at that concentration, not a potency): 3.56%
Compound 4: middle estimate off by 30.4 percentage points, on the high side, outside the stated range (below it).
By their numbers in this assay, from the lowest: compounds 2 and 4 (each within the scatter of the next); then compounds 3 and 1 (each within the scatter of the next).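

Ethoxy on an aromatic carbon, para to a large group, brings a number 32.1 percentage points lower from compound 1 to compound 4 (beyond the scatter) in this assay. The earlier ring change, tert-butyl in place of hydrogen, gave a number 2.9 percentage points lower from compound 1 to compound 3 (within the scatter), so among these compounds a group added to this aromatic ring can leave the read-out within the scatter or lower it sharply. The ethoxy step is as large as the step seen with the added methyl on the chain carbon, a number 32.1 percentage points lower from compound 1 to compound 2 (beyond the scatter), and nothing measured here explains the loss.

The compounds shown leave open whether the loss follows the ethoxy group itself or its place on the ring. A methoxy group or a chlorine atom in that same place, or ethoxy elsewhere on the ring, would help separate these two readings.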